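The source may hold more compounds than are shown below. What is called first, only, known or untested is meant among the compounds shown, and "the series" means these compounds.

Measured so far:
- compound 1, `COc1ccc(/C=N/NC(=O)Nc2ccc(Oc3ccnc(-c4nncn4CCN(C)C)c3)c(F)c2)c(OC)c1OC`: in a functional assay on A549 cells (Homo sapiens) for cytotoxicity, read by MTT assay, with a stated time of 72 h (a higher number here means a weaker inhibitor, a lower number a stronger inhibitor), compound 1 gives 6680 nM
- compound 2, `CN(C)CCn1cnnc1-c1cc(Oc2ccc(NC(=O)N/N=C/c3c(O)ccc4ccccc34)cc2F)ccn1`: in this assay compound 2 gives 880 nM

Within the data shown here, compound 2 stands at the stronger end of the two numbers known so far, and its only neighbour is compound 1, which lies well above it. Among the measured compounds shown here, the single measured step, a 7.6-fold lower number from compound 1 to compound 2 (0.88 log units; beyond the scatter), shows that exchanging the aromatic group attached to the carbon with a double bond to nitrogen can move the result by a clear margin.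

Compound 3, `CN(C)CCn1cnnc1-c1cc(Oc2ccc(NC(=O)N/N=C/c3cc(Br)c(O)c(Br)c3)cc2F)ccn1`, has not yet been measured in this assay. It differs from compound 2 in one place: 3,5-dibromo-4-hydroxyphenyl in place of 2-hydroxynaphthalen-1-yl on a carbon with a double bond to nitrogen. The measured step from compound 1 to compound 2 bears on this change only loosely, since it concerns the same position but a different pair of groups; it does say that a swap here can matter. With no closer comparison, the expectation is a moderate shift, most likely toward a somewhat weaker inhibitor, but without confidence in direction. The expected step is a 1.7-fold higher number from compound 2 to compound 3 (0.23 log units; within the scatter). For compound 3 the estimated value in this assay is 1500 nM, with a range from 400 nM to 5000 nM.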

Compound 3, half-maximal inhibitory concentration: > 100000 nM
Compound 3: only a limit was reported; the forecaster's own chance of this, stated with the estimate: 5%; at least 66-fold (1.82 log units) between middle value and limit.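

The number for compound 3 is a limit of the assay and not a measured value: the limit of > 100000 nM in this assay, at which 1 of the 3 values shown sits. Among these compounds, compounds 1 and 2 both gave readable numbers, so they showed only that a swap at this place can shift the result, whereas 3,5-dibromo-4-hydroxyphenyl in place of 2-hydroxynaphthalen-1-yl brings an at least 110-fold higher number from compound 2 to compound 3 (2.05 log units; beyond the scatter), a far larger move than a 7.6-fold lower number from compound 1 to compound 2 (0.88 log units; beyond the scatter). The same group in place of 2,3,4-trimethoxyphenyl brings an at least 14-fold higher number from compound 1 to compound 3 (1.17 log units; beyond the scatter), so in this assay it is the weakest of the three groups shown on the carbon with a double bond to nitrogen, and the choice of group here can decide whether a usable number is obtained at all.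

The change from compound 2 to compound 3 adds two bromine atoms and leaves one aromatic ring where there were two, so the compounds shown cannot say which of these matters. From the compounds shown here alone, it also remains open where a phenyl ring carrying only a hydroxy group, or one carrying an amine, would fall in this assay.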